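Adding a chloro to compound 3

The source may hold more compounds than are shown below. What is called first, only, known or untested is meant among the compounds shown, and "the series" means these compounds.

Three closely related compounds have been measured in a functional assay on SR cells (Homo sapiens) for inhibition, read by sulforhodamine B assay, with a stated time of 48 h; a lower number here means a stronger inhibitor of growth, a higher number a weaker inhibitor of growth. Compound 1 (`O=C(Nc1cccc(-n2cc(-c3ccncc3)c(-c3ccc(Cl)c(O)c3)n2)c1)Nc1cccc(C(F)(F)F)c1`) gives 1820 nM, compound 2 (`COc1cc(-c2nn(-c3cccc(NC(=O)Nc4cc(C(F)(F)F)cc(C(F)(F)F)c4)c3)cc2-c2ccncc2)ccc1Cl`) gives 1080 nM, and compound 3 (`COc1cc(-c2nn(-c3cccc(NC(=O)c4cccc(C(F)(F)F)c4)c3)cc2-c2ccncc2)ccc1Cl`) gives 838 nM. Compound 3 and compound 2 lie within the scatter of each other, while the number of compound 1 stands higher than that of compound 3, beyond the scatter.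

Compound 4 (`COc1cc(-c2nn(-c3cccc(NC(=O)c4ccc(Cl)c(C(F)(F)F)c4)c3)cc2-c2ccncc2)ccc1Cl`) is compound 3 with chloro in place of hydrogen on an aromatic carbon, which turns 3-(trifluoromethyl)phenyl into 4-chloro-3-(trifluoromethyl)phenyl: chloro in place of hydrogen on an aromatic carbon. The chloro stands ortho to a trifluoromethyl group and para to a large group. For the measured compounds named here, no measured pair shows this change alone, so the expectation in this assay has little to rest on: a step no larger than the scatter, with a slight lean towards a lower number. The estimated change is a 1.2-fold lower number from compound 3 to compound 4 (0.08 log units; within the scatter). Compound 4 is estimated at 700 nM, with an expected range from 280 nM to 1700 nM.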

Compound 4, concentration for 50% growth inhibition: 848 nM
Compound 4: the middle estimate sits 1.2-fold (0.08 log units) below what was measured, within the range that was stated.
By their numbers in this assay, from the lowest: compounds 3, 4, 2 and 1 (each within the scatter of the next, the first and the last beyond it).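

In this assay, chloro in place of hydrogen on an aromatic carbon, ortho to a trifluoromethyl group and para to a large group, gives a 1.0-fold higher number from compound 3 to compound 4 (0.01 log units; within the scatter), so the two compounds cannot be told apart. For the compounds shown here, this is the first step that differs in one place only, and it shows that this position of the 3-(trifluoromethyl)phenyl ring accepts a chloro with no step beyond the scatter, which the earlier compounds, differing in more than one place, could not show. No evidence is at hand that bears on this result.

From the compounds shown here alone, whether a larger or different group at this position, such as an amine, a methoxy or a carboxylic acid, would give a step beyond the scatter remains open. Also open, going by these compounds, is whether the same chloro would read alike on the core of compound 1.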